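The source may report more compounds than this note shows. Statements on the series, on what has been measured and on what is new or still open speak of the compounds shown alone.

Of the compounds shown here, two of one shared core have been measured in a functional assay on CHO cells for agonist activity at adenosine receptor A1 (Homo sapiens), read by fluorescence and ERK phosphorylation, with stated times of 30 min and 1.5 h, tested at 3 uM; a higher number here means a stronger effect of the compound at the concentration tested, a lower number a weaker effect. Compound 1, with structure `Nc1scc(-c2cccc(C(F)(F)F)c2)c1C(=O)c1ccccc1`, gives 83% in this assay. Compound 2, with structure `Nc1scc(-c2ccccc2F)c1C(=O)c1ccccc1`, gives 55% in this assay. Of the two numbers seen so far, compound 2 stands lowest, and its nearest neighbour compound 1 lies higher by a gap beyond the usual scatter of such measurements.

The next compound to be measured is compound 3, with structure `Nc1scc(-c2ccc(F)cc2)c1C(=O)c1ccccc1`. It differs from compound 2 in one place: 4-fluorophenyl in place of 2-fluorophenyl on an aromatic carbon. The two have the same atoms, joined differently. Among the compounds with values here, no pair of measured compounds shows this kind of change, so there is no measured step to lean on. The expectation is that the step of a number 10 percentage points higher from compound 2 to compound 3 (within the scatter) will be small and upward, at most around the edge of the scatter rather than clearly beyond it. On that basis compound 3 is estimated to give 65% in this assay, with a range from 40% to 88%.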

Compound 3, a percentage reported as activity, at one concentration (the size of the read-out at that concentration, not a potency): 51%
For compound 3 the middle estimate is 14 percentage points above the measured one; the measured number falls inside the stated range.
By their numbers in this assay, from the lowest: compounds 3 and 2 (each within the scatter of the next); then compound 1.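

Compound 2 and compound 3 carry the same atoms, and only the fluorine sits elsewhere on the phenyl ring, yet 4-fluorophenyl in place of 2-fluorophenyl gives a number 4 percentage points lower from compound 2 to compound 3 (within the scatter) in this assay. Within the data shown here, this is the first step seen at this position of the shared core, on an aromatic carbon of the five-membered ring, and it shows that these two fluorophenyl isomers cannot be told apart at the single concentration tested. Nothing available here offers an explanation for that outcome.

From the compounds shown here alone, this single pair says nothing about other groups at this position, so it remains open how a plain phenyl ring, or a phenyl ring carrying a methoxy group, an amine or a carboxylic acid, would compare with these two. Going by these compounds, the read-out also gives the size of the effect at one concentration and not a potency, so it stays open whether compound 2 and compound 3 would also match across a full range of concentrations.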